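This account rests on a few compounds, and the source may have more. Where it says the series, first, only, none or still open, it means among the compounds named here.

Measured compounds:
- compound 1, `CC1=C(c2cccc(O)c2)C(c2ccc(OC[C@@H](C)N3CC[C@H](C)C3)cc2)Oc2ccc(O)cc21`: 0.2 nM
- compound 2, `CC1=C(c2ccccc2)C(c2ccc(OC[C@H](C)N3CC[C@@H](C)C3)cc2)Oc2ccc(O)cc21`: 0.4 nM
- compound 3, `CC1=C(c2ccc(O)cc2)C(c2ccc(OC[C@H](C)N3CC[C@@H](C)C3)cc2)Oc2ccc(O)cc21`: 0.1 nM

All three were tested in a functional assay on MCF7 cells (Homo sapiens) for antiproliferative activity, read by CellTiter-Glo, with a stated time of 5 days; a lower number here means a stronger inhibitor, a higher number a weaker inhibitor. Compound 1 sits between the other two: its gap to compound 2 and its gap to compound 3 are each within the scatter, so the three numbers cannot be told apart with confidence. Among the measured compounds shown here, the one step that can be read between measured compounds is a 4.0-fold lower number from compound 2 to compound 3 (0.60 log units; beyond the scatter), and that step concerns a hydroxy group on an aromatic ring, not the part of the molecule that changes here.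

Compound 4, `CC1=C(c2cccc(O)c2)C(c2ccc(OC[C@H](C)N3CCCCCC3)cc2)Oc2ccc(O)cc21`, differs from compound 1 in this way: a group of 9 heavy atoms (8 carbon, 1 nitrogen; one seven-membered non-aromatic ring with 1 hetero atom) in place of a group of 8 heavy atoms (7 carbon, 1 nitrogen; one five-membered non-aromatic ring with 1 hetero atom), on a saturated chain carbon bound to an oxygen on an aromatic ring. For the measured compounds named here, no measured pair differs in the ring attached to that saturated chain carbon, so nothing in the data speaks directly to this change. The expectation for compound 4 in this assay is therefore a number close to that of compound 1, with a step of a 1.5-fold higher number from compound 1 to compound 4 (0.18 log units; within the scatter) that is not expected to pass beyond the scatter. Compound 4 is estimated at 0.3 nM, with a range from 0.1 nM to 1 nM.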

Compound 4, half-maximal inhibitory concentration: 0.2 nM
Compound 4: middle estimate off by 1.5-fold (0.18 log units), on the high side; the measured number falls inside the stated range.
By their numbers in this assay, from the lowest: compounds 3, 1, 4 and 2 (each within the scatter of the next, the first and the last beyond it).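

In this assay, putting the seven-membered non-aromatic ring in place of the five-membered one gives no change at the digits printed from compound 1 to compound 4 (within the scatter). This is the only measured change at this place among the compounds shown, and it indicates that, on this saturated chain carbon bound to an oxygen on an aromatic ring, the group with 9 heavy atoms and 1 defined stereocentre can replace the group with 8 heavy atoms and 2 defined stereocentres without a readable shift in the number. Nothing available here accounts for this result.

The compounds shown leave open whether a morpholine ring or an open-chain diethylamino group would hold the number at this place. They also leave open what a carboxylic acid there, with no ring nitrogen at all, would give.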